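The source may report more compounds than this note shows. Statements on the series, on what has been measured and on what is new or still open speak of the compounds shown alone.

Compound 1 `O=S1(=O)C=Cc2ccc(Nc3cccc(C(F)(F)F)c3)cc21`: 1310 nM
Compound 2 `O=S1(=O)C=Cc2ccc(Nc3ccc(C(F)(F)F)cc3)cc21`: 1300 nM

In a functional assay on MDA-MB-231 cells (Homo sapiens) for antiproliferative activity, read by MTT assay, with a stated time of 72 h (on this read-out higher numbers stand for weaker inhibition and lower numbers for stronger inhibition), compound 2 gives 1300 nM, level within the usual scatter with compound 1 at 1310 nM. Compound 3 `O=S1(=O)C=Cc2ccc(Nc3ccc(Cl)cc3)cc21` has not yet been measured. Compared with compound 2, it carries chloro in place of trifluoromethyl on an aromatic carbon, para to a large group: chloro in place of trifluoromethyl on an aromatic carbon. Among the measured compounds shown here, no measured step shows what this swap does, so any forecast here is rough. The expected change is a 1.2-fold higher number from compound 2 to compound 3 (0.06 log units; within the scatter), which would stay within the scatter and has no firm direction. Compound 3 is estimated at 1500 nM, with a likely range of 600 nM to 3600 nM.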

Compound 3, half-maximal inhibitory concentration: 6720 nM
Compound 3: middle estimate off by 4.5-fold (0.65 log units), on the low side; measured number above the stated range.
By their numbers in this assay, from the lowest: compounds 2 and 1 (each within the scatter of the next); then compound 3.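

In this assay, putting chloro in place of trifluoromethyl on this aromatic carbon, para to a large group, gives a 5.2-fold higher number from compound 2 to compound 3 (0.71 log units; beyond the scatter). This position therefore does respond to a change of group, something compound 1 and compound 2 could not show, as both carry trifluoromethyl and their values lie within the scatter of each other. Nothing measured here explains the step. From the compounds shown here alone, whether a nitrile, a methoxy or an amine on this carbon would stay near compound 2 or resemble compound 3 remains open.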